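Furan-2-yl in place of 4-chlorophenyl: a step from the limit

This account rests on a few compounds, and the source may have more. Where it says the series, first, only, none or still open, it means among the compounds named here.

Measured compounds:
compound 1 `COc1ccc(-n2nc(C(C)=O)s/c2=N\c2nc(-c3c(C)n(C)n(-c4ccccc4)c3=O)cs2)cc1`: 64500 nM
compound 2 `CCOC(=O)c1nn(-c2ccc(C)cc2)/c(=N/c2nc(-c3c(C)n(C)n(-c4ccccc4)c3=O)cs2)s1`: > 100000 nM
compound 3 `Cc1c(-c2csc(/N=C3\S/C(=C\c4ccc(Cl)cc4)C(=O)N3c3ccccc3)n2)c(=O)n(-c2ccccc2)n1C`: > 100000 nM

Three compounds were measured in a functional assay on MCF7 cells (Homo sapiens) for cytotoxicity, read by sulforhodamine B assay, with a stated time of 72 h; on this read-out lower numbers stand for stronger inhibition and higher numbers for weaker inhibition. Compound 1 gives 64500 nM in this assay. For compound 2 the read-out is a limit of the assay, > 100000 nM. For compound 3 the read-out is likewise a limit of the assay, > 100000 nM. So compound 3 stands not on a number but on a limit, and the only evidence on these numbers is the limit of > 100000 nM in this assay, at which 2 of the 3 values shown sit.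

Compound 4 `Cc1c(-c2csc(/N=C3\S/C(=C\c4ccco4)C(=O)N3c3ccccc3)n2)c(=O)n(-c2ccccc2)n1C` has not yet been measured. It differs from compound 3 in one place: furan-2-yl in place of 4-chlorophenyl on a double-bonded chain carbon bound to a double-bonded ring carbon. Among the measured compounds shown here, no step between measured compounds is available, so the size of such a change cannot be read from any measured pair. Because compound 3 sits at the limit of > 100000 nM in this assay, at which 2 of the 3 values shown sit, the expectation for compound 4 in this assay is no step beyond the scatter in either direction, and a fair chance that the read-out is once more only a limit. Compound 4 is expected to give 100000 nM in this assay, within a range from 40000 nM to 300000 nM. The step this estimate means is a number no higher from compound 3 to compound 4 (the limit leaves the size open), which is expected to stay within the usual scatter.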

Compound 4, half-maximal inhibitory concentration: 22400 nM
Compound 4: the middle estimate sits 4.5-fold (0.65 log units) above what was measured; the measured number lies below the stated range.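

In this assay, the place on a double-bonded chain carbon bound to a double-bonded ring carbon proves able to move the read-out: furan-2-yl in place of 4-chlorophenyl gives an at least 4.4-fold lower number from compound 3 to compound 4 (0.64 log units; beyond the scatter). Among the compounds shown here, compound 4 gives a real number, 22400 nM, and this pair is the first to show that a change in one place on this scaffold can register beyond the scatter. The true size of the step remains unknown because the value of compound 3 is a limit, so the step sets only a minimum: the limit of > 100000 nM in this assay, at which 2 of the 4 values shown sit.

The compounds shown leave open whether this shift belongs to furan-2-yl in particular, or whether thiophene-2-yl, pyridin-3-yl, an unsubstituted phenyl or a simple methyl group at the same place would give a similar read-out. On these data alone, compound 4 also cannot be set against compound 1 or compound 2, which differ from it in more than one place, so how this change compares with changes elsewhere in the molecule also stays open.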